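The source may hold more compounds than are shown below. What is called first, only, known or untested is meant among the compounds shown, and "the series" means these compounds.

Working notes on the series. Compound 1 `C[C@@H](Cn1ccc(-c2ccc(C#N)c(Cl)c2)n1)NC(=O)c1ccccc1` gives 1830 nM in a functional assay on LNCaP cells (Homo sapiens) for antiproliferative activity, read by CCK-8 assay, with a stated time of 6 days; a higher number here means a weaker inhibitor, a lower number a stronger inhibitor. Compound 2 `C[C@@H](Cn1ccc(-c2ccc(C#N)c(Cl)c2)n1)NC(=O)c1ccccc1F` gives 1810 nM; the step of a 1.0-fold lower number from compound 1 to compound 2 (0.00 log units; within the scatter) shows no difference between the two. Compound 3 `C[C@@H](Cn1ccc(-c2ccc(C#N)c(Cl)c2)n1)NS(=O)(=O)c1cccnc1` gives 6140 nM, the highest number among the three measured compounds; the steps reaching it are a 3.4-fold higher number from compound 1 to compound 3 (0.53 log units; beyond the scatter) and a 3.4-fold higher number from compound 2 to compound 3 (0.53 log units; beyond the scatter), both modest and both beyond the scatter.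

Compound 4 `C[C@@H](Cn1ccc(-c2ccc(C#N)c(Cl)c2)n1)NS(=O)(=O)c1cn(C)cn1` has not been measured. The change from compound 3 is 1-methyl-1H-imidazol-4-yl in place of pyridin-3-yl on a sulfonyl sulfur. Among the measured compounds shown here, no measured step exchanges one aromatic ring for another on the sulfonyl sulfur; the two steps that reach compound 3 concern the amide-to-sulfonamide exchange and bear on compound 4 only by fixing the starting number. With nothing pointing in either direction, the expected step in this assay is one within the scatter, a 1.1-fold higher number from compound 3 to compound 4 (0.02 log units; within the scatter), and the range is kept wide for want of a precedent. Compound 4 is therefore estimated at 6500 nM, with a range of 2500 nM to 17000 nM.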

Compound 4, half-maximal inhibitory concentration: > 30000 nM
Compound 4 gave a limit, no number; the forecaster's own chance of this, stated with the estimate: 10%; at least 4.6-fold (0.66 log units) between middle value and limit.
By their numbers in this assay, from the lowest: compounds 2 and 1 (each within the scatter of the next); then compound 3. At a limit, above all of these: compound 4.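

In this assay compound 4 gives a limit and not a number: the limit of > 30000 nM in this assay, at which 1 of the 4 values shown sits. Among the compounds shown here, this is the first exchange of one aromatic ring for another on the sulfonyl sulfur, and 1-methyl-1H-imidazol-4-yl in place of pyridin-3-yl is an at least 4.8-fold higher number from compound 3 to compound 4 (0.68 log units; beyond the scatter), so the ring at this position is not freely interchangeable. Measured against the amides, the gap is an at least 16-fold higher number from compound 2 to compound 4 (1.21 log units; beyond the scatter) and an at least 16-fold higher number from compound 1 to compound 4 (1.21 log units; beyond the scatter), both larger than the steps that reach compound 3.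

As far as these compounds go, how far beyond the limit compound 4 lies stays open. Also open, from the compounds shown here alone, is whether a plain phenyl or a pyridin-3-yl carrying an amine on the sulfonyl sulfur would behave like pyridin-3-yl, and whether 1-methyl-1H-imidazol-4-yl on a carbonyl would show the same loss.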